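A few compounds are considered here, and "the series" means these few. Any claim that something is new, unique, unknown or untested is made for them only; others in the source may bear on it.

Series notes, step from compound 1 to compound 3.

Compound 1 `Cc1ccc(-n2nc(-c3ccccc3)nc2CNc2ccc(C(=O)NO)cc2)cc1` is the reference point of the pair measured so far. In an assay on Sf9 cells for inhibition of protein deacetylase HDAC6 (Homo sapiens), read by fluorescence, with a stated time of 40 min (a lower number here means a stronger inhibitor, a higher number a weaker inhibitor), compound 1 gives 310 nM. Among the compounds with values here, the only other measured member, compound 2 `O=C(NO)c1ccc(NCc2nc(-c3cc4ccccc4s3)nn2-c2ccccc2)cc1`, carries a different substituent on the shared core and in this assay compound 2 gives 324 nM. Compound 1 holds the lower of the two numbers, but the gap to compound 2 lies within the usual scatter, so the two compounds are treated as indistinguishable in this assay on present data.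

Compound 3 `O=C(NO)c1ccc(NCc2nc(-c3ccccc3)nn2-c2ccc(F)cc2)cc1` has not yet been measured. It differs from compound 1 in one place: fluoro in place of methyl on an aromatic carbon, on an aromatic carbon of a six-membered aromatic ring of carbon only. Within the data shown here, no matched step of this kind exists among the measured compounds, so there is nothing to calibrate the size of the change against. The substituent leaving and the one entering are each a single heavy atom without donor or acceptor, and the step from compound 1 to compound 3 is expected to be small, a 1.1-fold higher number from compound 1 to compound 3 (0.05 log units; within the scatter), with no clear direction beyond the scatter. For compound 3 in this assay the estimate is 350 nM, in a range from 150 nM to 800 nM.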

Compound 3, half-maximal inhibitory concentration: 274 nM
Estimate against measurement, compound 3: 1.3-fold (0.11 log units) above; measured number inside the range.
By their numbers in this assay, from the lowest: compounds 3, 1 and 2 (each within the scatter of the next).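

Within the data shown here, the 4-methylphenyl to 4-fluorophenyl change gives the series its first matched step: in this assay it reads as a 1.1-fold lower number from compound 1 to compound 3 (0.05 log units; within the scatter) and so supplies a first measure for an exchange of this kind. On this aromatic carbon, para to a large group, methyl and fluoro are interchangeable as far as this read-out can tell, and compound 1 and compound 3 are treated as indistinguishable on present data. Nothing at hand bears on why the two groups read alike.

The compounds shown cover only these two small groups at this carbon, so it remains open whether the position stays as flat with an amine, a carboxylic acid, a methoxy group or a longer chain in the same place. On these data alone, the step also rests on a single pair with the core of compound 1, and compound 2 has no matched partner, so whether the same exchange reads alike on a different substitution of the shared core is unknown.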